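Changing the ring on the amine nitrogen: a forecast

The compounds below may be only part of what the source reports. "The series", "measured", "known", "first", "only" and "open" are said of these compounds alone.

Measured in an assay on CHO cells for displacement of a labelled ligand from adenosine receptor A1 (Homo sapiens), read by scintillation counting, with a stated time of 120 min, tested at 10 uM; a higher number here means more inhibition at the concentration tested (going by the name of the read-out), a lower number less inhibition:
compound 1 `Nc1scc(CN2CCN(c3cccc(Cl)c3Cl)CC2)c1C(=O)c1ccc(Cl)cc1`: 2%
compound 2 `Nc1scc(CN2CCN(c3ccc(Cl)cc3F)CC2)c1C(=O)c1ccc(Cl)cc1`: 0%
compound 3 `Nc1scc(CN2CCN(c3cccc(C(F)(F)F)c3)CC2)c1C(=O)c1ccc(Cl)cc1`: 0%

Compound 3 stands level with compound 2 at the digits shown, the two together the lowest of the three, and the step of a number 2 percentage points lower from compound 1 to compound 3 (within the scatter) shows that compound 1 is within the scatter of it as well. Compound 4 `Nc1scc(CN2CCN(c3ccncc3)CC2)c1C(=O)c1ccc(Cl)cc1` differs from compound 3 by pyridin-4-yl in place of 3-(trifluoromethyl)phenyl on an amine nitrogen in a ring. Among the measured compounds shown here, the steps that bear on this change are a number 2 percentage points lower from compound 1 to compound 2 (within the scatter), a number 2 percentage points lower from compound 1 to compound 3 (within the scatter) and no change at the digits printed from compound 2 to compound 3 (within the scatter), each within the scatter; none of them involves a ring with a hetero atom, so they only show that varying this ring has so far moved nothing. For compound 4 a step of a number 1 percentage points higher from compound 3 to compound 4 (within the scatter) is therefore expected, no change beyond the scatter. Compound 4 is estimated at 1%, with a range from -6% to 10%.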

Compound 4, a percentage reported as inhibition, at one concentration (the size of the read-out at that concentration, not a potency): 1%
The estimate for compound 4 equals the measured number at the digits printed, within the range that was stated.
By their numbers in this assay, from the lowest: compounds 2, 3, 4 and 1 (each within the scatter of the next).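

In this assay the pyridin-4-yl ring of compound 4, the only ring here with a hetero atom, gives a number 1 percentage points higher from compound 3 to compound 4 (within the scatter) and a number 1 percentage points higher from compound 2 to compound 4 (within the scatter) and a number 1 percentage points lower from compound 1 to compound 4 (within the scatter) and so stays level with all three carbon-only rings. A ring nitrogen with its hydrogen-bond acceptor, and fewer heavy atoms than trifluoromethylphenyl, therefore moves nothing beyond the scatter at this position. No evidence on hand explains this result.

Still open, going by these compounds, is whether a ring carrying an amine or a carboxylic acid would lift the number at this position. Whether a longer chain in place of the ring would do so is equally unsettled.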